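The source may hold more compounds than are shown below. What is called first, only, known or untested is meant among the compounds shown, and "the series" means these compounds.

Working notes on the series. Compound 1 (`COc1ccc(/C=C/C(=O)/C=C/c2cc3ccccc3nc2Oc2ccccc2)cc1OC`) reads > 10000 nM in a functional assay on HGC-27 cells (Homo sapiens) for cytotoxicity, read by MTT assay, with a stated time of 48 h (a higher number here means a weaker inhibitor, a lower number a stronger inhibitor), and this is a limit, not a number. For the measured compounds named here, compound 2 (`COc1cc(OC)c(OC)cc1/C=C/C(=O)/C=C/c1cc2ccccc2nc1Oc1ccccc1`) gives 10500 nM in this assay, the only true number so far. Going by the values given here, the one measured step, a step that the limit leaves unreadable from compound 1 to compound 2, has no readable size because of the limit of > 10000 nM in this assay, at which 1 of the 2 values shown sits, so it offers no scale for the next change. Compound 3 (`COc1cc(OC)c(OC)cc1/C=C/C(=O)/C=C/c1cc2ccccc2nc1Oc1cccc(Cl)c1`) differs from compound 2 by chloro in place of hydrogen on an aromatic carbon, which is chloro in place of hydrogen on an aromatic carbon, turning phenoxy to 3-chlorophenoxy. Among the compounds with values here, no measured step involves chloro, so no step beyond the scatter is expected in this assay, and no direction can be argued firmly. The expected change is a 1.3-fold lower number from compound 2 to compound 3 (0.12 log units; within the scatter). For compound 3 the estimated value is 8000 nM, with an expected range of 2500 nM to 20000 nM.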

Compound 3, half-maximal inhibitory concentration: > 10000 nM
Compound 3: a limit, no number (the forecaster's own chance of this, stated with the estimate: 25%); at least 1.2-fold (0.09 log units) between middle value and limit.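

No new step can be read from compound 2 to compound 3, because compound 3 gives only a limit: the limit of > 10000 nM in this assay, at which 2 of the 3 values shown sit.
The compounds shown leave open whether chloro in place of hydrogen, phenoxy to 3-chlorophenoxy, shifts the reading in this assay at all, and in which direction.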